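Working notes: aromatic-nitrogen substituent change, compound 3 to compound 4

This account rests on a few compounds, and the source may have more. Where it says the series, first, only, none or still open, it means among the compounds named here.

Measured compounds:
compound 1 `CCOC(=O)C(=O)CC(=O)/C=C/c1cn(C=C(C)C)c2ccccc12`: > 40 uM
compound 2 `CCOC(=O)C(=O)CC(=O)/C=C/c1cn(-c2ccc(Cl)cc2)c2ccccc12`: > 40 uM
compound 3 `O=C(/C=C/c1cn(-c2ccc(Cl)cc2)c2ccccc12)CC(=O)C(=O)O`: 31 uM

In an assay on isolated protein for inhibition of DNA nucleotidylexotransferase (Homo sapiens), read by scintillation counting, with a stated time of 10 min (on this read-out lower numbers stand for stronger inhibition and higher numbers for weaker inhibition), compound 1 gives > 40 uM, which is a limit of the assay. Compound 2 gives > 40 uM, also a limit. For the measured compounds named here, compound 3 gives 31 uM, the only number among the three; the other two sit at the limit of > 40 uM in this assay, at which 2 of the 3 values shown sit. The step that the two limits leave unreadable from compound 1 to compound 2 is therefore unreadable, and the step of an at least 1.2-fold lower number from compound 2 to compound 3 (0.11 log units; that floor lies within the scatter) is a floor within the scatter.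

Compound 4 `O=C(/C=C/c1cn(CC(=O)N2CCOCC2)c2ccccc12)CC(=O)C(=O)O` differs from compound 3 in one place: ((morpholin-4-yl)carbonyl)methyl in place of 4-chlorophenyl on an aromatic nitrogen. Going by the values given here, the only measured step on the aromatic nitrogen, a step that the two limits leave unreadable from compound 1 to compound 2, gives no readable size, so no step in this assay is expected beyond the scatter, with wide uncertainty. Compound 4 is estimated at 35 uM, between 10 uM and 120 uM, an expected step of a 1.1-fold higher number from compound 3 to compound 4 (0.05 log units; within the scatter).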

Compound 4, concentration for 50% inhibition: 24 uM
Estimate against measurement, compound 4: 1.5-fold (0.16 log units) above, within the range that was stated.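

In this assay, for the compounds shown here, the substituent change is a 1.3-fold lower number from compound 3 to compound 4 (0.11 log units; within the scatter) and gives the first readable step on the aromatic nitrogen. The two groups are not told apart here, although ((morpholin-4-yl)carbonyl)methyl brings a non-aromatic ring and 2 hydrogen-bond acceptors where 4-chlorophenyl has an aromatic ring and none. On this evidence the position accepts either group, with the carboxylic acid end of the molecule held constant. Still open, on these data alone, is whether an amine, such as 2-aminoethyl, or a longer alkyl chain on this nitrogen would shift the number beyond the scatter.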